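The source may hold more compounds than are shown below. What is called first, only, known or untested is meant among the compounds shown, and "the series" means these compounds.

Measured compounds:
- Compound 1 `Cc1cc(S(N)(=O)=O)ccc1NC(=O)COc1ccc(Cl)cc1Oc1ccc2ccccc2c1Br`: in an ADME assay on C8166 cells (Homo sapiens) for cytotoxicity, read by MTT assay (a higher number here means that more compound is tolerated, a lower number that less compound is tolerated), compound 1 gives 48100 nM.
- Compound 2 `Cc1cc(S(N)(=O)=O)ccc1NC(=O)COc1ccc(F)cc1Oc1ccc2ccccc2c1Br`: in this assay compound 2 gives 39500 nM.

Compound 1 stands at the higher of the two numbers, with compound 2 close enough that the two values cannot be told apart. Within the data shown here, the only measured step, a 1.2-fold lower number from compound 1 to compound 2 (0.09 log units; within the scatter), swaps one halogen for another on the shared core and shows that this exchange leaves the tolerated concentration essentially unchanged.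

Compound 3 `Cc1cc(S(N)(=O)=O)ccc1NC(=O)COc1ccc(Cl)cc1Oc1c(C)cc2ccccc2c1Cl` differs from compound 1 in a different part of the molecule: 1-chloro-3-methylnaphthalen-2-yl in place of 1-bromonaphthalen-2-yl on an oxygen on an aromatic ring. The measured step bears on it only loosely, since here the halogen exchange is joined by an added methyl group, for which no comparison exists. On this basis the step of a 1.1-fold lower number from compound 1 to compound 3 (0.03 log units; within the scatter) is expected to stay within the scatter, and compound 3 is estimated to give 45000 nM in this assay, with a range from 20000 nM to 100000 nM.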

Compound 3, half-maximal cytotoxic concentration: 42600 nM
The estimate for compound 3 lay 1.1-fold (0.02 log units) above the measured number; low and high end bracket the measured number.
By their numbers in this assay, from the lowest: compounds 2, 3 and 1 (each within the scatter of the next).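

Exchanging 1-bromonaphthalen-2-yl for 1-chloro-3-methylnaphthalen-2-yl on an oxygen on an aromatic ring gives a 1.1-fold lower number from compound 1 to compound 3 (0.05 log units; within the scatter) in this assay. The earlier step changed only one halogen for another elsewhere on the shared core, whereas this one shows that a second part of the molecule can take a different halogen and an added methyl group with no detectable shift in the tolerated concentration. Nothing measured here speaks to the reason for this result.

Going by these compounds, the methyl group and the halogen exchange arrive together, so what each does alone stays unknown, and the two might offset each other. On these data alone, whether the tolerated concentration would also hold with an amine or a carboxylic acid in this part of the molecule, or with a longer chain in place of the methyl group, remains open.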